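The compounds below may be only part of what the source reports. "The series", "measured", "known", "first", "only" and "open" are said of these compounds alone.

Measured compounds:
compound 1, `O=c1c(O)c(O)oc2ccc(Cl)cc12` — in a functional assay on the whole organism for inhibition, with Homo sapiens as the target (a lower number here means a stronger inhibitor, a higher number a weaker inhibitor), compound 1 gives 2380000 nM.
compound 2, `O=C1C(O)=C(O)OC12CCCC2` — compound 2 reaches only a limit of the assay, > 4000000 nM in this assay.
compound 3, `O=c1c(O)c(O)oc2ccc(O)cc12` — compound 3 likewise reaches only a limit, > 4000000 nM in this assay.

Compound 3 therefore has no number of its own in this assay, only a limit, and it shares that position with one other compound (the limit of > 4000000 nM in this assay, at which 2 of the 3 values shown sit). Among the measured compounds shown here, the one step among the measured compounds, an at least 1.6-fold higher number from compound 1 to compound 3 (0.22 log units; that floor lies within the scatter), is itself only a floor, and that floor lies within the scatter. Compound 4, `CC(C)(C)c1cc2oc(O)c(O)c(=O)c2cc1O`, differs from compound 3 by tert-butyl in place of hydrogen on an aromatic carbon. For the measured compounds named here, no measured step concerns a tert-butyl group; the only measured step, hydroxy for chloro, bears on a different exchange and offers no guide to the size or direction of this one. The expectation is thus no step beyond the scatter, and the step from compound 3 to compound 4 is estimated as a number no higher from compound 3 to compound 4 (the limit leaves the size open). Compound 4 is expected to give 4000000 nM in this assay, between 1500000 nM and 8000000 nM, most probably again only as a limit.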

Compound 4, half-maximal inhibitory concentration: > 4000000 nM
Compound 4: no number, only a limit; the forecaster's own chance of this, stated with the estimate: 70%; the middle value sits exactly at the limit.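

Among the compounds shown here, compound 4, like compound 3, reaches only a limit in this assay, so no step between the two can be read. The compounds shown leave open whether tert-butyl in place of hydrogen on an aromatic carbon changes inhibition at all, as most values stop at one point: the limit of > 4000000 nM in this assay, at which 3 of the 4 values shown sit.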